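The source may hold more compounds than are shown below. What is called first, only, known or untested is meant among the compounds shown, and "the series" means these compounds.

Measured compounds in a functional assay on SiHa cells (Homo sapiens) for cytotoxicity, with a stated time of 4 h; a higher number here means a weaker inhibitor, a lower number a stronger inhibitor:
- compound 1, `[O-][n+]1nc(NCCN2CCCCC2)[n+]([O-])c2cc(Cl)ccc21`: 200 nM
- compound 2, `CCCN(CCC)CCNc1n[n+]([O-])c2ccc(Cl)cc2[n+]1[O-]`: 300 nM
- compound 3, `CC(C)c1ccc2c(c1)[n+]([O-])c(NCCN1CCCCC1)n[n+]2[O-]`: 1100 nM

Compounds 1 and 2 share a core and differ only in the side chain: dipropylamino in place of piperidin-1-yl on a saturated chain carbon, two bonds along the chain from a nitrogen on an aromatic ring. This change gives a 1.5-fold higher number from compound 1 to compound 2 (0.18 log units; within the scatter), so the two values are treated as equivalent. Compound 3 keeps the side chain of compound 1 but carries a different core, the difference being (isopropyl in place of chloro on an aromatic carbon). That change gives a 5.5-fold higher number from compound 1 to compound 3 (0.74 log units; beyond the scatter), and compound 3 stands highest of the three numbers; against compound 2 its value is also clearly higher.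

Compound 4, `CCCN(CCC)CCNc1n[n+]([O-])c2ccc(C(C)C)cc2[n+]1[O-]`, is not yet measured. It carries the core of compound 3 and the side chain of compound 2. Relative to compound 3 the change is dipropylamino in place of piperidin-1-yl on a saturated chain carbon, two bonds along the chain from a nitrogen on an aromatic ring. This is the same change as that from compound 1 to compound 2, at the same place, and it occurs twice among the compounds here. For the measured compounds named here, the only precedent is the step of a 1.5-fold higher number from compound 1 to compound 2 (0.18 log units; within the scatter), which lies within the scatter.

Going by the values given here, for compound 4 the expected step in this assay is a 1.5-fold higher number from compound 3 to compound 4 (0.16 log units; within the scatter), set beside the earlier 1.5-fold higher number from compound 1 to compound 2 (0.18 log units; within the scatter), because a 1.5-fold higher number from compound 1 to compound 2 (0.18 log units; within the scatter) is the only measured instance of this change and it shows no clear movement. Whether the change behaves the same on the core of compound 3 is not tested here. The estimate for compound 4 is 1600 nM, expected to lie between 700 nM and 3600 nM.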

Compound 4, half-maximal inhibitory concentration: 900 nM
Beside the measured number, compound 4's estimate is 1.8-fold (0.25 log units) above it; the measured number falls inside the stated range.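

In this assay, dipropylamino in place of piperidin-1-yl on the core of compound 3 gives a 1.2-fold lower number from compound 3 to compound 4 (0.09 log units; within the scatter), and this side-chain change carries over from the core of compound 1 with no clear movement on either core: the same change on two cores in this assay, a 1.5-fold higher number (0.18 log units; within the scatter) from compound 1 to compound 2 and a 1.2-fold lower number (0.09 log units; within the scatter) from compound 3 to compound 4, 1.8-fold (0.26 log units) apart, within the scatter of two such steps.

With the dipropylamino side chain held fixed, isopropyl in place of chloro gives a 3.0-fold higher number from compound 2 to compound 4 (0.48 log units; beyond the scatter), so this change raises the number with either side chain, and the size of the step agrees across the two: the same change on two cores in this assay, a 5.5-fold higher number (0.74 log units; beyond the scatter) from compound 1 to compound 3 and a 3.0-fold higher number (0.48 log units; beyond the scatter) from compound 2 to compound 4, 1.8-fold (0.26 log units) apart, within the scatter of two such steps.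

Across these four compounds the two changes therefore read as additive, but that rests on just two side chains, two aromatic substituents and a single cell assay at one exposure time, and it gives no reason for either result or any assurance that the agreement would hold on a further core.

Still open, as far as these compounds go, is whether the rise in the number follows from isopropyl specifically or would also appear with other groups at that aromatic carbon, such as methoxy, trifluoromethyl or plain hydrogen. On the side-chain end, a morpholine ring, a primary amine or a longer chain to the terminal amine would show whether the flat response extends beyond piperidin-1-yl and dipropylamino.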